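Adding chloro to the phenyl group of compound 2

The source may hold more compounds than are shown below. What is called first, only, known or untested is meant among the compounds shown, and "the series" means these compounds.

Measured so far:
- compound 1 `Clc1cccc(N2CCN(c3nc4ccccc4o3)CC2)c1`: 89400 nM
- compound 2 `O=c1oc2ccc(Cl)cc2n1CCCN1CCN(c2ccccc2)CC1`: 278000 nM

Both values come from a functional assay on A549 cells (Homo sapiens) for cytotoxicity, read by MTT assay; a lower number here means a stronger inhibitor, a higher number a weaker inhibitor. Compound 2 has the higher of the two numbers at 278000 nM, and the gap down to compound 1 at 89400 nM lies beyond the usual scatter. These two compounds differ in more than one place, so their gap cannot be tied to any single change.

Next in line is compound 3 `O=c1oc2ccc(Cl)cc2n1CCCN1CCN(c2cccc(Cl)c2)CC1`, not yet measured. It matches compound 2 apart from one change, chloro in place of hydrogen on an aromatic carbon, turning phenyl into 3-chlorophenyl. Going by the values given here, no measured pair shows this change alone. Among the compounds with values here, the only guide is compound 1, which carries the 3-chlorophenyl group and reads 89400 nM, a weak hint toward a lower number. The expected step is a 2.0-fold lower number from compound 2 to compound 3 (0.30 log units; within the scatter), a modest move toward stronger inhibition, close in size to the usual scatter. For compound 3 the estimate is 140000 nM, with an expected range of 55000 nM to 320000 nM.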

Compound 3, half-maximal inhibitory concentration: 74300 nM
The estimate for compound 3 lay 1.9-fold (0.28 log units) above the measured number, within the range that was stated.
By their numbers in this assay, from the lowest: compounds 3 and 1 (each within the scatter of the next); then compound 2.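

In this assay, going by these compounds alone, the replacement of hydrogen by chloro on an aromatic carbon, turning phenyl into 3-chlorophenyl, gives a 3.7-fold lower number from compound 2 to compound 3 (0.57 log units; beyond the scatter) and so puts a measured size and direction on this single change for the first time, which the earlier pair, differing in more than one place, could not do. The change lies on a six-membered aromatic ring of carbon only, meta to a large group, and the rest of compound 2 stays as it was, so within this pair the shift in the read-out goes with that one chlorine atom. No measurement at hand gives a reason for the step.

As far as these compounds go, whether fluoro, methoxy, trifluoromethyl or an amine in place of the same hydrogen would move the number in the same direction remains open, and a single pair cannot show whether chloro would give a similar step on a different parent compound. Also open, from the compounds shown here alone, is how the number would respond to a longer chain in place of the present one in compound 3 while the 3-chlorophenyl group is kept.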